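The compounds below may be only part of what the source reports. "The series", "measured", "known", "first", "only" and "open" are said of these compounds alone.

Compound 3 `COc1cc(-n2cnc3ccc(-c4ccccc4Cl)cc32)cc(OC)c1OC` in a functional assay on A549 cells (Homo sapiens) for antiproliferative activity, read by MTT assay, with a stated time of 72 h (a higher number here means a weaker inhibitor, a lower number a stronger inhibitor), gives only a limit, > 10000 nM, not a number; it sits at the limit of > 10000 nM in this assay, at which 1 of the 3 values shown sits. Compound 1 `COc1cccc(-c2ccc3ncn(-c4cc(OC)c(OC)c(OC)c4)c3c2)c1` in this assay gives 3180 nM, and compound 2 `COc1cc(-n2cnc3ccc(-c4cccc(C)c4C)cc32)cc(OC)c1OC` gives 9250 nM. The steps of a 2.9-fold higher number from compound 1 to compound 2 (0.46 log units; beyond the scatter) and an at least 3.1-fold higher number from compound 1 to compound 3 (0.49 log units; beyond the scatter) both raise the number on leaving the 3-methoxyphenyl, while an at least 1.0-fold higher number from compound 2 to compound 3 (0.03 log units; that floor lies within the scatter) stays within the scatter. Compound 4 `COc1cc(-n2cnc3ccc(-c4cccc([N+](=O)[O-])c4)cc32)cc(OC)c1OC` differs from compound 3 by 3-nitrophenyl in place of 2-chlorophenyl on an aromatic carbon. Compound 4 thus carries a 3-nitrophenyl where compound 1 carries a 3-methoxyphenyl; a nitro group is not a methoxy group, so the return toward compound 1 is uncertain. A downward step of roughly an at least 1.8-fold lower number from compound 3 to compound 4 (0.25 log units; that floor lies within the scatter) is expected, with a fair chance that only a limit is again recorded. Compound 4 is estimated at 5500 nM, within 1500 nM to 20000 nM.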

Compound 4, half-maximal inhibitory concentration: 5410 nM
The estimate for compound 4 lay 1.0-fold (0.01 log units) above the measured number, within the range that was stated.
By their numbers in this assay, from the lowest: compounds 1, 4 and 2 (each within the scatter of the next, the first and the last beyond it). At a limit, above all of these: compound 3.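

With the 3-nitrophenyl, this assay again yields a number, yet an at least 1.8-fold lower number from compound 3 to compound 4 (0.26 log units; that floor lies within the scatter) is only a floor: the limit of > 10000 nM in this assay, at which 1 of the 4 values shown sits.

Nitro in place of methoxy does not separate the two compounds, as a 1.7-fold higher number from compound 1 to compound 4 (0.23 log units; within the scatter) stays within the scatter. The 3-nitrophenyl is likewise not separated from the 2,3-dimethylphenyl, with a 1.7-fold lower number from compound 2 to compound 4 (0.23 log units; within the scatter) also within the scatter.

Open, from the compounds shown here alone, is whether an amine or a carboxylic acid in place of the nitro on this phenyl would move the number beyond the scatter of compound 1, in either direction.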